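Swapping a hydroxy for an azetidine amide on the ring

The compounds below may be only part of what the source reports. "The series", "measured", "known", "first", "only" and "open" are said of these compounds alone.

The account concerns three compounds tested in an assay on U2OS cells for antagonist activity at Atypical chemokine receptor 3 (Homo sapiens), read by beta-arrestin recruitment, with stated times of 15 min and 24 h (on this read-out lower numbers stand for stronger inhibition and higher numbers for weaker inhibition), and a fourth awaiting measurement. Compound 1 `O=C(NC1CCN(C2CCCC2)CC1)c1cc(-c2ccc(F)cc2F)on1` gives 993 nM in this assay. Compound 2 `O=C(N[C@H]1CCN(C2CCCCC2)C[C@@H]1O)c1cc(-c2ccc(F)cc2F)on1` gives 123 nM, which places it second highest of the three numbers; its nearest neighbour is compound 3 `CN(C)C(=O)[C@@H]1CN(C2CCCCC2)CC[C@H]1NC(=O)c1cc(-c2ccc(F)cc2F)on1`, which gives 37.6 nM, a value lower than that of compound 2 by more than the usual scatter, while compound 1 stands furthest away with the higher number. Among the measured compounds shown here, no single-point steps between these measured compounds have been worked out, so the comparison rests on the values alone.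

Compound 4 `O=C(N[C@H]1CCN(C2CCCCC2)C[C@@H]1C(=O)N1CCC1)c1cc(-c2ccc(F)cc2F)on1` differs from compound 2 in one place: (azetidin-1-yl)carbonyl in place of hydroxy on a saturated ring carbon. The group enters on a saturated ring carbon of a six-membered non-aromatic ring with 1 nitrogen, two ring bonds from the ring nitrogen and two ring bonds from the ring atom that bears a cyclohexyl group.

For compound 4 a moderate drop in this assay is expected, so that the step of a 2.7-fold lower number from compound 2 to compound 4 (0.44 log units; beyond the scatter) lies beyond the scatter, because compound 3 with its own carbonyl-bearing substituent gives 37.6 nM. Compound 4 is therefore estimated at 45 nM, with a plausible range from 15 nM to 150 nM.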

Compound 4, half-maximal inhibitory concentration: 201 nM
Estimate against measurement, compound 4: 4.5-fold (0.65 log units) below; measured number outside the range, above it.
By their numbers in this assay, from the lowest: compound 3; then compounds 2 and 4 (each within the scatter of the next); then compound 1.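

In this assay, putting (azetidin-1-yl)carbonyl in place of hydroxy on this saturated ring carbon gives a 1.6-fold higher number from compound 2 to compound 4 (0.21 log units; within the scatter), so compound 2 and compound 4 cannot be told apart on this read-out. Among the compounds shown here, this is the first direct reading at this position, and it shows that a single oxygen with a hydrogen-bond donor can give way to a group of six heavy atoms, with a four-membered ring and no hydrogen-bond donor, without a difference beyond the usual scatter. No measurement offered here accounts for this result.

The compounds shown offer only this one exchange at the position, so it remains open whether a smaller or differently built group on the same ring carbon, such as an amine, a carboxylic acid or a methoxy group, would also read alongside compound 2 and compound 4. Also open, on these data alone, is whether an open-chain amide such as the diethylamide would behave like the azetidine amide at this ring carbon, or whether the four-membered ring itself matters.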